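The source may hold more compounds than are shown below. What is called first, only, known or untested is meant among the compounds shown, and "the series" means these compounds.

Among the measured compounds shown here, in a functional assay on HeLa cells (Homo sapiens) for cytotoxicity, read by MTT assay, with a stated time of 48 h (a higher number here means a weaker inhibitor, a lower number a stronger inhibitor), compound 2 (`C=C1CCC[C@]2(C)CCC(c3cn(-c4cccc([N+](=O)[O-])c4)nn3)=CC[C@@]12C`) gives 31900 nM, the higher of the two numbers so far, and compound 1 (`C=C1CCC[C@]2(C)CCC(c3cn(-c4ccc(C(C)=O)cc4)nn3)=CC[C@@]12C`) gives 15100 nM. For the measured compounds named here, the only measured step, a 2.1-fold higher number from compound 1 to compound 2 (0.32 log units; beyond the scatter), is modest. Compound 3 (`C=C1CCC[C@]2(C)CCC(c3cn(-c4ccc(I)cc4)nn3)=CC[C@@]12C`) has 4-iodophenyl in place of 3-nitrophenyl on an aromatic nitrogen. Going by the values given here, no compound with this group has been measured, so that one step is the only guide to size. Compound 1, with 4-acetylphenyl, stands at 15100 nM, so a step in this assay toward a lower number, no larger than the measured one, is expected. The expected change is a 1.6-fold lower number from compound 2 to compound 3 (0.20 log units; within the scatter). For compound 3 the estimate is 20000 nM, with an expected range of 9000 nM to 45000 nM.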

Compound 3, half-maximal inhibitory concentration: 144000 nM
Compound 3: middle estimate off by 7.2-fold (0.86 log units), on the low side; the measured number lies above the stated range.
By their numbers in this assay, from the lowest: compound 1; then compound 2; then compound 3.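

In this assay, the group on the aromatic nitrogen can shift the number much further than the first pair showed: 4-iodophenyl in place of 3-nitrophenyl gives a 4.5-fold higher number from compound 2 to compound 3 (0.65 log units; beyond the scatter), and iodo in place of acetyl on an aromatic carbon gives a 9.5-fold higher number from compound 1 to compound 3 (0.98 log units; beyond the scatter). Both steps lie beyond the scatter, so compound 3 is the weakest of the three. Nothing available explains this result. Compounds 2 and 3 differ in both group and ring position, so the two effects remain unseparated. From the compounds shown here alone, an amine or a carboxylic acid in place of iodo remains open.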